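Amide Replacements for Bromo on an Adenosine Deaminase Inhibitor Scaffold

A few compounds are considered here, and "the series" means these few. Any claim that something is new, unique, unknown or untested is made for them only; others in the source may bear on it.

Compound 1: `C[C@H](O)[C@@H](CCc1cccc(Br)c1)n1cnc2c(N)ncnc21`, 0.6 nM
Compound 2: `C[C@H](O)[C@@H](CCc1cccc(C(N)=O)c1)n1cnc2c(N)ncnc21`, 2.9 nM
Compound 3: `C[C@H](O)[C@@H](CCc1cccc(C(=O)N(C)C)c1)n1cnc2c(N)ncnc21`, 1.8 nM

Three compounds sharing one core were tested in an assay on isolated protein for inhibition of adenosine deaminase (Bos taurus), with a stated time of 5 min (on this read-out higher numbers stand for weaker inhibition and lower numbers for stronger inhibition), and compound 1 gives the lowest of the three numbers. Its nearest neighbour is compound 3, a step of a 3.0-fold higher number from compound 1 to compound 3 (0.48 log units; beyond the scatter), and the furthest is compound 2, a step of a 4.8-fold higher number from compound 1 to compound 2 (0.68 log units; beyond the scatter). Between the two amides the step of a 1.6-fold lower number from compound 2 to compound 3 (0.21 log units; within the scatter) lies within the scatter.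

Compound 4, `C[C@H](O)[C@@H](CCc1cccc(C(=O)NC2CCCC2)c1)n1cnc2c(N)ncnc21`, is not yet measured. It differs from compound 1 in one place: cyclopentylcarbamoyl in place of bromo on an aromatic carbon. The two measured steps that bear on this change are the ones from compound 1 to the carbamoyl and dimethylcarbamoyl analogues, both modest and both toward higher numbers; cyclopentylcarbamoyl is a third amide at the same aromatic carbon. In this assay a step of similar size and direction is therefore expected, a 3.3-fold higher number from compound 1 to compound 4 (0.52 log units; beyond the scatter). Compound 4 is estimated at 2 nM, with a range from 0.7 nM to 6 nM.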

Compound 4, inhibition constant: 1.8 nM
Beside the measured number, compound 4's estimate is 1.1-fold (0.05 log units) above it; low and high end bracket the measured number.
By their numbers in this assay, from the lowest: compound 1; then compounds 3, 4 and 2 (each within the scatter of the next).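

In this assay a third amide at this aromatic carbon, now carrying a five-membered non-aromatic ring of carbon only, gives a 3.0-fold higher number from compound 1 to compound 4 (0.48 log units; beyond the scatter) and leaves compound 1 with the lowest number of the four, with no amide going against that. The new information concerns the amide nitrogen: cyclopentylamino in place of dimethylamino gives no change at the digits printed from compound 3 to compound 4 (within the scatter) and cyclopentyl in place of hydrogen gives a 1.6-fold lower number from compound 2 to compound 4 (0.21 log units; within the scatter) and neither step can be read as a difference. With hydrogen, dimethyl or cyclopentyl on that nitrogen, the three amides cannot be told apart here.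

From the compounds shown here alone, whether a carboxylic acid, an amine or a longer chain on the amide nitrogen would stay with these amides remains open. Nothing shown accounts for the gap between bromo and the amides.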